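Chloro to methyl on the benzyl group: compound 3 to compound 4

The compounds below may be only part of what the source reports. "The series", "measured", "known", "first", "only" and "open" are said of these compounds alone.

Measured in an ADME assay on L6 cells (Rattus norvegicus) for cytotoxicity, read by resazurin assay, with a stated time of 70 h; on this read-out higher numbers stand for weaker inhibition and lower numbers for stronger inhibition:
- compound 1 `CC(=O)Oc1ccc2c(c1)C(C)=CC(C)(C)N2Cc1ccc(C)cc1`: 21000 nM
- compound 2 `COc1cc(OC)cc(C(=O)Oc2ccc3c(c2)C(C)=CC(C)(C)N3Cc2ccccc2)c1`: 24000 nM
- compound 3 `COc1cc(OC)cc(C(=O)Oc2ccc3c(c2)C(C)=CC(C)(C)N3Cc2ccc(Cl)cc2)c1`: > 190000 nM

Compound 3 gives only a limit of this assay, > 190000 nM, and not a number. It is the only reading of this kind in the set: the limit of > 190000 nM in this assay, at which 1 of the 3 values shown sits.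

Compound 4 `COc1cc(OC)cc(C(=O)Oc2ccc3c(c2)C(C)=CC(C)(C)N3Cc2ccc(C)cc2)c1` keeps the core and the ester of compound 3 and has methyl in place of chloro on an aromatic carbon, para to a large group: methyl in place of chloro on an aromatic carbon.

Within the data shown here, one measured step bears directly on this place: chloro in place of hydrogen gave an at least 7.9-fold higher number from compound 2 to compound 3 (0.89 log units; beyond the scatter). Its true size is open, since it ends at a limit. A second clue is that the 4-methylbenzyl group of compound 4 also occurs, with a different ester, in compound 1. Compound 1 gives 21000 nM. Among the measured compounds shown here, no measured step links compound 1 to compound 4, so this reading carries less weight.

With chloro gone, a move back towards compound 2 at 24000 nM is expected, though perhaps not all the way. A limit reading remains possible. The expected change is an at least 3.1-fold lower number from compound 3 to compound 4 (0.50 log units; beyond the scatter). For compound 4 the estimated value is 60000 nM, with an expected range of 18000 nM to 180000 nM.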

Compound 4, half-maximal inhibitory concentration: > 200000 nM
Compound 4 was reported as a limit (the forecaster's own chance of this, stated with the estimate: 30%); middle value at least 3.3-fold (0.52 log units) away from the limit.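

In this assay compound 4 gives > 200000 nM, which is a limit and not a number. Methyl in place of hydrogen on the benzyl group gave an at least 8.3-fold higher number from compound 2 to compound 4 (0.92 log units; beyond the scatter), and chloro in place of hydrogen gave an at least 7.9-fold higher number from compound 2 to compound 3 (0.89 log units; beyond the scatter), so at this position the higher number is not tied to chloro alone, although the step between the two limits of compound 3 and compound 4 cannot be read. With the 4-methylbenzyl group held constant, 3,5-dimethoxyphenyl in place of methyl on the carbonyl carbon gave an at least 9.5-fold higher number from compound 1 to compound 4 (0.97 log units; beyond the scatter), so the 4-methylbenzyl group alone does not set the reading and the ester also counts.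

As far as these compounds go, how far compound 3 and compound 4 lie beyond their limits stays open, and with it any order between chloro and methyl at this place. Also open, from the compounds shown here alone, is whether a methoxy group, an amine or a carboxylic acid in the same place on the benzyl group would give a measurable number in this assay or another limit.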